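The source may report more compounds than this note shows. Statements on the series, on what has been measured and on what is new or still open speak of the compounds shown alone.

Of the compounds shown here, two that share one core have been measured in a functional assay on MCF7 cells (Homo sapiens) for cytotoxicity, read by MTT assay, with a stated time of 72 h; on this read-out higher numbers stand for weaker inhibition and lower numbers for stronger inhibition. Compound 1 `CNC(=O)c1cc(Oc2ccc(NC(=O)c3nn(-c4ccccc4C(F)(F)F)c(=O)cc3C)cc2F)ccn1` gives 35700 nM in this assay. Compound 2 `Cc1cc(=O)n(-c2ccccc2C(F)(F)F)nc1C(=O)Nc1ccc(Oc2ncnc3sccc23)c(F)c1` gives 13800 nM in this assay, the lower of the two numbers, and the step of a 2.6-fold lower number from compound 1 to compound 2 (0.41 log units; beyond the scatter) came from exchanging the ring system attached to the ether oxygen. Compound 3 `Cc1ccc(-n2nc(C(=O)Nc3ccc(Oc4ncnc5sccc45)c(F)c3)c(C)cc2=O)cc1` has not yet been measured and differs from compound 2 at a different place: 4-methylphenyl in place of 2-(trifluoromethyl)phenyl on an aromatic nitrogen. Going by the values given here, no measured step touches this position, so the single known step, a 2.6-fold lower number from compound 1 to compound 2 (0.41 log units; beyond the scatter), gives only indirect guidance: it shows that a change on this core can move the number modestly, nothing more. Compound 3 is therefore expected to land close to compound 2, most likely with no step beyond the scatter. The expected step is a 1.3-fold higher number from compound 2 to compound 3 (0.12 log units; within the scatter). Compound 3 is estimated to give about 18000 nM in this assay, within a range of 6000 nM to 55000 nM.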

Compound 3, half-maximal inhibitory concentration: > 40000 nM
Compound 3: no number, only a limit; the forecaster's own chance of this, stated with the estimate: 10%; at least 2.2-fold (0.34 log units) between middle value and limit.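

In this assay compound 3 gives > 40000 nM, which is a limit of the assay and not a number. Going by these compounds alone, putting 4-methylphenyl in place of 2-(trifluoromethyl)phenyl on the aromatic nitrogen gives an at least 2.8-fold higher number from compound 2 to compound 3 (0.46 log units; beyond the scatter), so this position, which no earlier step touched, does affect the read-out, and the change here moves the number upward. The full size of this step stays unknown, since only a bound on it can be read: the limit of > 40000 nM in this assay, at which 1 of the 3 values shown sits.

The two groups differ both in the substituent and in where it sits on the phenyl ring, so the compounds shown cannot separate these two changes. They also do not tell how a plain phenyl, or a phenyl ring carrying an amine or a carboxylic acid, would behave on this nitrogen.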